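Replacing a Large Side Group with Chlorine

This account rests on a few compounds, and the source may have more. Where it says the series, first, only, none or still open, it means among the compounds named here.

In an ADME assay on HeLa cells (Homo sapiens) for cytotoxicity (on this read-out lower numbers stand for stronger inhibition and higher numbers for weaker inhibition), compound 2 `Cc1ncc([N+](=O)[O-])n1CCSC(=S)N1CCC(OC(=O)CSC(=S)N2CCCCC2)CC1` gives 980 ug/mL, the highest number among the three measured compounds. Compound 1 `Cc1ncc([N+](=O)[O-])n1CCSC(=S)N1CCCCC1C` gives 170 ug/mL in this assay, and compound 3 `Cc1ncc([N+](=O)[O-])n1CCSC(=S)N1C(C)CCCC1C` gives 130 ug/mL; both of these numbers lie beyond the scatter below that of compound 2, so compound 2 is the weakest of the three at inhibiting these cells.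

Compound 4 `Cc1ncc([N+](=O)[O-])n1CCSC(=S)N1CCC(OC(=O)CCl)CC1` is obtained from compound 2 by the change (one chlorine atom in place of a group of 9 heavy atoms (6 carbon, 1 nitrogen, 2 sulfur; one six-membered non-aromatic ring with 1 hetero atom), on a saturated chain carbon bound to a carbonyl carbon). Going by the values given here, the only measured step, a 1.3-fold lower number from compound 1 to compound 3 (0.12 log units; within the scatter), concerns a methyl group added to a saturated ring carbon of the core and says nothing about trading a large ring-bearing group for a single chlorine atom on the ester side chain. Among the compounds with values here, no measured step therefore bears on this change, and the expectation for compound 4 rests on the value of compound 2 alone, with wide uncertainty. The step from compound 2 to compound 4 is expected to be a 2.0-fold lower number from compound 2 to compound 4 (0.29 log units; within the scatter), which is no more than a guess toward a somewhat lower number. Compound 4 is accordingly estimated at 500 ug/mL in this assay, within a range from 150 ug/mL to 1600 ug/mL.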

Compound 4, half-maximal inhibitory concentration: 930 ug/mL
Estimate against measurement, compound 4: 1.9-fold (0.27 log units) below; the measured number falls inside the stated range.
By their numbers in this assay, from the lowest: compounds 3 and 1 (each within the scatter of the next); then compounds 4 and 2 (each within the scatter of the next).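

In this assay the result at this place is a 1.1-fold lower number from compound 2 to compound 4 (0.02 log units; within the scatter) and so leaves the two compounds indistinguishable. The earlier compounds shown here spoke only to a methyl group on a saturated ring carbon of the core, whereas this pair shows that, on a saturated chain carbon bound to a carbonyl carbon, a whole group of 9 heavy atoms, including a six-membered non-aromatic ring, can give way to a single chloro while the read-out stays within the usual scatter. Nothing measured here offers an explanation for how little the number responds to such a large swap.

Only chloro and this one large group are shown at this place, so what an amine, a carboxylic acid or a longer chain would give there remains an open question. As far as these compounds go, whether an amide in place of the ester that carries this side chain would give a number in the same range is equally open.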